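A few compounds are considered here, and "the series" means these few. Any claim that something is new, unique, unknown or untested is made for them only; others in the source may bear on it.

Compound 1, `CC(=O)N[C@@H](CSC(=O)Nc1ccc(I)cc1)C(=O)O`, gives > 200000 nM.
Compound 2, `COc1ccccc1NC(=O)SC[C@H](NC(C)=O)C(=O)O`, gives > 200000 nM.
Compound 3, `CC(=O)N[C@@H](CSC(=O)Nc1ccc(F)cc1)C(=O)O`, gives > 200000 nM.

In a functional assay on OVCAR-3 cells (Homo sapiens) for cytotoxicity, read by MTT assay, with a stated time of 6 days (a higher number here means a weaker inhibitor, a lower number a stronger inhibitor), compound 3 stands at a limit of the assay, not at a number. Compound 1 sits at that same limit. Compound 2 sits there as well, so that the limit of > 200000 nM in this assay, at which 3 of the 3 values shown sit, describes everything measured. For the measured compounds named here, the one step between measured compounds, a step that the two limits leave unreadable from compound 1 to compound 3, is unreadable between two limits and gives no size. Compound 4, `CC(=O)N[C@@H](CSC(=O)Nc1ccccc1)C(=O)O`, differs from compound 3 by hydrogen in place of fluoro on an aromatic carbon. Going by the values given here, no measured step shows a readable size or direction, so the step of a number no higher from compound 3 to compound 4 (the limit leaves the size open) is expected to be none beyond the scatter. Compound 4 is thus expected to give 200000 nM in this assay, within 100000 nM to 400000 nM, most likely again only as a limit.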

Compound 4, half-maximal inhibitory concentration: 153000 nM
Estimate against measurement, compound 4: 1.3-fold (0.12 log units) above; the range from low to high includes it.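

Hydrogen in place of the ring substituent gives the first reading in this assay that is a number rather than a limit, and this reads the same for all three groups: an at least 1.3-fold lower number from compound 3 to compound 4 (0.11 log units; that floor lies within the scatter) for fluoro, an at least 1.3-fold lower number from compound 1 to compound 4 (0.11 log units; that floor lies within the scatter) for iodo, and an at least 1.3-fold lower number from compound 2 to compound 4 (0.11 log units; that floor lies within the scatter) for methoxy. Going by these compounds, each of these is only a floor, so the true size of each step stays open. Only compound 4 carries a number, and the others remain at a limit: the limit of > 200000 nM in this assay, at which 3 of the 4 values shown sit.

The compounds shown leave open whether an amine or a nitrile on the aromatic ring, or a methyl ester in place of the carboxylic acid, would move the number beyond the scatter.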